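Swapping the morpholin-4-yl group of compound 3

A few compounds are considered here, and "the series" means these few. Any claim that something is new, unique, unknown or untested is made for them only; others in the source may bear on it.

Measured in a functional assay on KYSE-450 cells (Homo sapiens) for inhibition, read by CCK-8 assay, with a stated time of 48 h; a lower number here means a stronger inhibitor, a higher number a weaker inhibitor
- Compound 1 `COc1ccc(CN(C(=O)CSc2nc3ccccc3o2)c2cc(OC)c(OC)c(OC)c2)cc1`: 840 nM
- Compound 2 `COc1ccc(CN(C(=O)CSC(=S)N2CCN(C(C)=O)CC2)c2cc(OC)c(OC)c(OC)c2)cc1`: 370 nM
- Compound 3 `COc1ccc(CN(C(=O)CSC(=S)N2CCOCC2)c2cc(OC)c(OC)c(OC)c2)cc1`: 7220 nM

Compound 3 has the highest number of the three, making it the weakest inhibitor here. Compound 4 `COc1ccc(CN(C(=O)CSC(=S)N2CCc3ccccc32)c2cc(OC)c(OC)c(OC)c2)cc1` differs from it in one group, 2,3-dihydro-1H-indol-1-yl in place of morpholin-4-yl on a thiocarbonyl carbon on a thiocarbonyl carbon. Among the measured compounds shown here, two measured steps bear on this. The closest, a 20-fold higher number from compound 2 to compound 3 (1.29 log units; beyond the scatter) and made at that same carbon, shows how far this group can move the number. The other, an 8.6-fold higher number from compound 1 to compound 3 (0.93 log units; beyond the scatter), starts from a group that also holds a six-membered aromatic ring of carbon only, as the entering group does. A moderate fall is therefore expected in this assay with a 4.8-fold lower number from compound 3 to compound 4 (0.68 log units; beyond the scatter) as the estimated size. The estimate for compound 4 is 1500 nM within 350 nM to 6000 nM as the expected range.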

Compound 4, half-maximal inhibitory concentration: 6940 nM
Beside the measured number, compound 4's estimate is 4.6-fold (0.67 log units) below it, and the stated range ends below it.
By their numbers in this assay, from the lowest: compound 2; then compound 1; then compounds 4 and 3 (each within the scatter of the next).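

Replacing morpholin-4-yl with 2,3-dihydro-1H-indol-1-yl on the thiocarbonyl carbon gives a 1.0-fold lower number from compound 3 to compound 4 (0.02 log units; within the scatter) in this assay, so a six-membered aromatic ring of carbon only in this group does not by itself shift the number. The gap to the 4-acetylpiperazin-1-yl group remains (a 19-fold higher number from compound 2 to compound 4 (1.27 log units; beyond the scatter)), and the change on the sulfur also leaves a clear gap (an 8.3-fold higher number from compound 1 to compound 4 (0.92 log units; beyond the scatter)). No measurement shown here explains these results.

Still open, from the compounds shown here alone, is whether the acetyl group matters: 4-methylpiperazin-1-yl or piperazin-1-yl with its free amine would test that.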